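Moving the methoxy group around the benzyl ether ring

The source may hold more compounds than are shown below. What is called first, only, known or untested is meant among the compounds shown, and "the series" means these compounds.

Measured compounds:
compound 1 `Cc1ccc(COc2ccc(-c3cc(CN4CCN(Cc5ccc(C(F)(F)F)cc5)CC4)no3)cc2)cc1`: 7500 nM
compound 2 `FC(F)(F)c1ccc(CN2CCN(Cc3cc(-c4ccc(OCc5ccccc5Cl)cc4)on3)CC2)cc1`: 3200 nM
compound 3 `COc1cccc(COc2ccc(-c3cc(CN4CCN(Cc5ccc(C(F)(F)F)cc5)CC4)no3)cc2)c1`: 1400 nM

In a functional assay on Mahlavu cells (Homo sapiens) for antiproliferative activity, read by sulforhodamine B assay, with a stated time of 72 h (on this read-out lower numbers stand for stronger inhibition and higher numbers for weaker inhibition), compound 3 gives the lowest number of the three. The step of a 5.4-fold lower number from compound 1 to compound 3 (0.73 log units; beyond the scatter) and the step of a 2.3-fold lower number from compound 2 to compound 3 (0.36 log units; beyond the scatter) both show that the aromatic ring on the benzyl ether carbon matters modestly. Compound 4 `COc1ccc(COc2ccc(-c3cc(CN4CCN(Cc5ccc(C(F)(F)F)cc5)CC4)no3)cc2)cc1` keeps the same atoms as compound 3 but arranged differently: 4-methoxyphenyl in place of 3-methoxyphenyl on a saturated chain carbon bound to an oxygen on an aromatic ring. Among the measured compounds shown here, none of the measured steps changes only the position of a substituent on that ring, so no direct precedent exists; the measured steps merely bound the likely size. A small step is therefore expected, a 1.4-fold higher number from compound 3 to compound 4 (0.15 log units; within the scatter), with a slightly higher number judged somewhat more likely than a lower one. Compound 4 is estimated at 2000 nM, within a range from 800 nM to 5000 nM.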

Compound 4, half-maximal inhibitory concentration: 4900 nM
For compound 4 the middle estimate is 2.5-fold (0.39 log units) below the measured one; the measured number falls inside the stated range.
By their numbers in this assay, from the lowest: compound 3; then compounds 2, 4 and 1 (each within the scatter of the next, the first and the last beyond it).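

In this assay, the same atoms placed differently give a 3.5-fold higher number from compound 3 to compound 4 (0.54 log units; beyond the scatter), so on this ring the position of the methoxy counts, not just its presence. With 4-methoxyphenyl, the ring shows no clear separation from the other two: a 1.5-fold higher number from compound 2 to compound 4 (0.19 log units; within the scatter) and a 1.5-fold lower number from compound 1 to compound 4 (0.18 log units; within the scatter), both within the scatter. Among these four compounds, only 3-methoxyphenyl stands apart from the others.

Nothing available explains this position effect. As far as these compounds go, it remains open whether a nitrile or an amine in place of the methoxy on 3-methoxyphenyl would keep the lower number.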